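From 1-acetylpiperidin-4-yl to pyrimidin-5-yl on a carbonyl

The source may hold more compounds than are shown below. What is called first, only, known or untested is meant among the compounds shown, and "the series" means these compounds.

In an ADME assay on CHO cells (Cricetulus griseus) for cytotoxicity (on this read-out higher numbers stand for weaker inhibition and lower numbers for stronger inhibition), compound 1 `CC(=O)N1CCC(C(=O)Nc2cc(Nc3cnccn3)nc(-c3ccnc(N4CCNCC4)c3)c2)CC1` reads > 20000 nM, which is a limit of the assay and not a number. Compound 2 `c1cc(-c2cccc(Nc3cnccn3)n2)cc(N2CCNCC2)c1` also stands at a limit, > 15000 nM. Compound 3 `FC(F)(F)c1ccnc(Nc2cccc(-c3ccnc(N4CCNCC4)c3)n2)c1` gives a number, 1000 nM.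

Compound 4 `O=C(Nc1cc(Nc2cnccn2)nc(-c2ccnc(N3CCNCC3)c2)c1)c1cncnc1` keeps the core of compound 1 but has pyrimidin-5-yl in place of 1-acetylpiperidin-4-yl on a carbonyl carbon. Compound 4 is expected to remain a weak inhibitor, as compound 2 does at its limit of > 15000 nM. The expected change, an at least 1.6-fold lower number from compound 1 to compound 4 (0.22 log units; that floor lies within the scatter), is modest and toward stronger inhibition in this assay. For compound 4 the estimated value is 12000 nM, with an expected range of 3000 nM to 30000 nM.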

Compound 4, half-maximal inhibitory concentration: > 20000 nM
Compound 4: only a limit was reported; the forecaster's own chance of this, stated with the estimate: 55%; at least 1.6-fold (0.22 log units) between middle value and limit.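

No step can be read from compound 1 to compound 4: each stands at a limit of the assay, not at a number. The compounds shown leave open whether pyrimidin-5-yl in place of 1-acetylpiperidin-4-yl on a carbonyl carbon changes the read-out at all.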